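This account rests on a few compounds, and the source may have more. Where it says the series, first, only, none or still open, it means among the compounds named here.

Measured compounds, values in a functional assay for agonist activity at Alpha-1B adrenergic receptor (Homo sapiens); a lower number here means that less compound is needed, a higher number that more compound is needed for the effect:
- compound 1, `CS(=O)(=O)c1ccc(F)cc1NCC1=NCCN1`: < 100000 nM; this is a limit of the assay, not a number.
- compound 2, `Cc1ccc(S(C)(=O)=O)c(NCC2=NCCN2)c1`: 141 nM.
- compound 3, `CS(=O)(=O)c1ccc(Cl)cc1NCC1=NCCN1`: 61.7 nM.

Compound 3 holds the lowest of the two numbers shown; the nearest is compound 2, with a 2.3-fold lower number from compound 2 to compound 3 (0.36 log units; beyond the scatter). The steps a step that the limit leaves unreadable from compound 1 to compound 2 and a step that the limit leaves unreadable from compound 1 to compound 3 cannot be sized, because of the limit of < 100000 nM in this assay, at which 1 of the 3 values shown sits.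

Compound 4, `CS(=O)(=O)c1ccc(C(F)(F)F)cc1NCC1=NCCN1`, is not yet measured. It differs from compound 3 by trifluoromethyl in place of chloro on an aromatic carbon. Among the compounds with values here, the only readable step at this position is the one from methyl to chloro, a 2.3-fold lower number from compound 2 to compound 3 (0.36 log units; beyond the scatter), which is modest. Nothing here shows how trifluoromethyl compares with chloro at this carbon, so compound 4 is expected to sit near compound 3, with a step of a 1.6-fold higher number from compound 3 to compound 4 (0.21 log units; within the scatter) that may well fall within the scatter. The estimate for compound 4 in this assay is 100 nM, with a range from 30 nM to 350 nM.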

Compound 4, half-maximal effective concentration: < 100000 nM
Compound 4: only a limit was reported (the forecaster's own chance of this, stated with the estimate: 5%); the middle value is on the limit's open side.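

In this assay compound 4 gives < 100000 nM as a limit and not a number. Within the data shown here, no step linking compound 4 to compound 1, compound 2 or compound 3 can be read, because of the limit: the limit of < 100000 nM in this assay, at which 2 of the 4 values shown sit. The compounds shown leave open how trifluoromethyl compares with chloro, methyl or fluoro at this aromatic carbon.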